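Fluoro for amino on the shared core: two matched pairs

The source may hold more compounds than are shown below. What is called first, only, known or untested is meant among the compounds shown, and "the series" means these compounds.

Measured so far:
compound 1 `CC(=O)OC(C)n1cnc2c(S)nc(N)nc21` – 160 nM
compound 2 `CC(=O)OCCOn1cnc2c(S)nc(N)nc21` – 4200 nM
compound 3 `CC(=O)OC(C)n1cnc2c(S)nc(F)nc21` – a limit of the assay only, > 500000 nM

In a functional assay on SW-620 cells (Homo sapiens) for inhibition (a higher number here means a weaker inhibitor, a lower number a stronger inhibitor), compound 1 gives 160 nM. Compound 2 gives 4200 nM, a higher number than compound 1 and beyond the scatter. How the core of compound 2 differs from that of compound 1 is not broken down here. Compound 3 reaches only a limit of the assay, > 500000 nM, and no number is known for it. From compound 1 to compound 3 the change is fluoro in place of amino on an aromatic carbon and the step is an at least 3100-fold higher number from compound 1 to compound 3 (3.49 log units; beyond the scatter).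

Compound 4 `CC(=O)OCCOn1cnc2c(S)nc(F)nc21` is not yet measured. It differs from compound 2 by fluoro in place of amino on an aromatic carbon, the same change at the same place. The step from compound 2 to compound 4 in this assay is expected to be a 480-fold higher number from compound 2 to compound 4 (2.68 log units; beyond the scatter), set beside the earlier one of an at least 3100-fold higher number from compound 1 to compound 3 (3.49 log units; beyond the scatter); this rests on the fact that compound 3 sits at the limit of > 500000 nM in this assay, at which 1 of the 3 values shown sits, and compound 4 starts from a higher number than compound 1 did. Compound 4 is therefore expected to reach the limit as well, with an estimate of 2000000 nM and a range from 300000 nM to 10000000 nM.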

Compound 4, half-maximal inhibitory concentration: > 500000 nM
Compound 4: no number, only a limit; the forecaster's own chance of this, stated with the estimate: 85%; the middle value lies beyond the limit too.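

In this assay, fluoro in place of amino on an aromatic carbon gives an at least 110-fold higher number from compound 2 to compound 4 (2.07 log units; beyond the scatter), and the direction of the step seen on the core of compound 1 also holds on the core of compound 2. Compound 4 gives only a limit of the assay, > 500000 nM. The shared direction is therefore shown on these two cores, but equal size of the step is not: the same change on two cores in this assay, an at least 3100-fold higher number (3.49 log units; beyond the scatter) from compound 1 to compound 3 and an at least 110-fold higher number (2.07 log units; beyond the scatter) from compound 2 to compound 4; the limit leaves it open whether they differ

The compounds shown leave open how far compound 3 and compound 4 lie apart, and whether the step holds on any third core. Also open, on these data alone, is whether another group at the same place, such as a methylamino group, a hydroxyl or a plain hydrogen, would give a value that can be read in this assay, and so show how much of the activity depends on the amino group itself.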